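The source may hold more compounds than are shown below. What is called first, only, known or untested is meant among the compounds shown, and "the series" means these compounds.

Measured compounds in a functional assay on DU-145 cells (Homo sapiens) for cytotoxicity, read by MTT assay; on this read-out higher numbers stand for weaker inhibition and lower numbers for stronger inhibition:

- compound 1 `CC(O)(CSc1ccc(F)cc1)c1nc(-c2ccc(Cl)cc2)no1`: 36300 nM
- compound 2 `CC(O)(CSc1ccc(Cl)cc1)c1nc(-c2ccccc2)no1`: 70700 nM
- compound 3 `CC(O)(CSc1ccc(Cl)cc1)c1nc(-c2ccc(F)c(Cl)c2)no1`: 500 nM

Compound 3 gives the lowest number of the three; compound 1 sits well above it and compound 2 further still, both gaps beyond the scatter. Among the measured compounds shown here, the one single-point step among the measured compounds is a 140-fold lower number from compound 2 to compound 3 (2.15 log units; beyond the scatter), which shows that the substitution on the ring attached to the shared core moves the number by a large amount.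

Compound 4 `CC(O)(CSc1ccc(Cl)cc1)c1nc(-c2ccc(Cl)cc2)no1` is not yet measured. It differs from compound 3 as follows: 4-chlorophenyl in place of 3-chloro-4-fluorophenyl on an aromatic carbon. The step to be judged is thus the reverse direction of decoration: compound 4 carries the 4-chlorophenyl group, which compound 1 carries as well, though compound 1 differs from compound 4 elsewhere in the molecule. On the numbers available, compound 1 with 4-chlorophenyl stands far above compound 3, and compound 2 with bare phenyl stands higher still, so the 3-chloro-4-fluorophenyl group of compound 3 is the one feature that accompanies the low number. Compound 4 is therefore expected to lose much of that, with a step of a 30-fold higher number from compound 3 to compound 4 (1.48 log units; beyond the scatter) in this assay toward a higher number. The estimate for compound 4 is 15000 nM, within a range of 3000 nM to 60000 nM.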

Compound 4, half-maximal inhibitory concentration: 14500 nM
Beside the measured number, compound 4's estimate is 1.0-fold (0.01 log units) above it; low and high end bracket the measured number.
By their numbers in this assay, from the lowest: compound 3; then compound 4; then compounds 1 and 2 (each within the scatter of the next).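

Within this assay, and with the rest of the molecule held constant, three groups can now be compared at the ring carbon between two ring nitrogen atoms. Adding the chloro alone gives only part of the gain, a 4.9-fold lower number from compound 2 to compound 4 (0.69 log units; beyond the scatter), whereas a 29-fold higher number from compound 3 to compound 4 (1.46 log units; beyond the scatter) shows that most of the low number of compound 3 is lost with 4-chlorophenyl in place of 3-chloro-4-fluorophenyl. The other point of variation, where chloro replaces fluoro on an aromatic carbon, now also has a reading: a 2.5-fold lower number from compound 1 to compound 4 (0.40 log units; beyond the scatter), a modest step, so the series responds at a second place in the molecule, though far less than to the large change from 3-chloro-4-fluorophenyl.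

On these data alone, it remains open whether the low number of compound 3 needs both halogens or follows mainly from one of them, which 3-chlorophenyl and 4-fluorophenyl at the same carbon would separate, and whether a methoxy or trifluoromethyl group there could take the place of either halogen. Nothing available explains the origin of these steps.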